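A few compounds are considered here, and "the series" means these few. Any claim that something is new, unique, unknown or untested is made for them only; others in the source may bear on it.

In an ADME assay on L02 cells (Homo sapiens) for cytotoxicity, read by MTT assay, with a stated time of 72 h (on this read-out lower numbers stand for stronger inhibition and higher numbers for weaker inhibition), compound 3 `C/C=C/C(=O)Nc1cccc(Oc2nc(Nc3cccc(OC)c3)nc3c2CSCC3)c1` gives > 50000 nM, which is a limit of the assay and not a number. Compound 1 `C/C=C/C(=O)Nc1cccc(Oc2nc(Nc3ccn(C)n3)nc3c2CSCC3)c1` gives > 50000 nM, which is also a limit. Compound 2 `CC(C)=CC(=O)Nc1cccc(Oc2nc(Nc3ccn(C)n3)nc3c2CSCC3)c1` gives > 50000 nM, again a limit. The whole set therefore rests on a single boundary: the limit of > 50000 nM in this assay, at which 3 of the 3 values shown sit. None of the three compounds has an exact value from which to measure a change.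

Compound 4 `COc1cccc(Nc2nc3c(c(Oc4cccc(NC(=O)C=C(C)C)c4)n2)CSCC3)c1` differs from compound 3 in one place, on a carbonyl carbon whose other neighbour is an amide-type nitrogen, where 2-methylprop-1-en-1-yl takes the place of prop-1-en-1-yl: 2-methylprop-1-en-1-yl in place of prop-1-en-1-yl on a carbonyl carbon.

The same replacement also separates another measured pair, and the result is a step that the two limits leave unreadable from compound 1 to compound 2. This is the closest guide, but it offers no size or direction to carry over. Exchanging 1-methyl-1H-pyrazol-3-yl for 3-methoxyphenyl on a nitrogen gives a step that the two limits leave unreadable from compound 1 to compound 3, which is equally silent on size. With no readable step to draw on, no step beyond the scatter is expected in this assay, in either direction. The estimated step is a step that the limit leaves unreadable from compound 3 to compound 4. For compound 4 the expected value is 60000 nM, with an estimated range from 30000 nM to 100000 nM. The most likely report is again only a limit.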

Compound 4, half-maximal inhibitory concentration: > 50000 nM
Compound 4: no number, only a limit (the forecaster's own chance of this, stated with the estimate: 90%); the middle value does not contradict the limit.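

Neither the step from compound 3 to compound 4 nor the step from compound 2 to compound 4 can be read in this assay, as each compares two limits and not two numbers. The compounds shown leave open whether either replacement changes the value at all, and in which direction, as all four sit at one boundary: the limit of > 50000 nM in this assay, at which 4 of the 4 values shown sit.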